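The source may report more compounds than this note shows. Statements on the series, on what has been measured and on what is new or still open speak of the compounds shown alone.

Of the compounds shown here, two have numbers so far in a functional assay on THP-1 cells (Homo sapiens) for activation; a higher number here means that more compound is needed for the effect, a lower number that less compound is needed. Compound 1 (`CC(C)(C)OC(=O)n1c(-c2ccc3c(c2)CC(NS(=O)(=O)c2ccccc2)C3)cc2ccccc21`) gives 680 nM, and compound 2 (`N#CCCc1ccc(-c2cc3ccccc3n2C(=O)c2ccccc2)cc1`) gives 51 nM. Compound 2 holds the lower of the two numbers, and the gap lies beyond the scatter. The next compound is compound 3 (`CC(C)(C)OC(=O)n1c(-c2ccc(CCC#N)cc2)cc2ccccc21`), which differs from compound 2 in one place: tert-butoxy in place of phenyl on a carbonyl carbon. Tert-butoxy stands in place of phenyl on a carbonyl carbon, so benzoyl gives way to tert-butoxycarbonyl.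

Going by the values given here, no measured pair isolates this change, so its size cannot be read directly from the series. Among the compounds with values here, the only guide is compound 1, which also carries tert-butoxycarbonyl and gives 680 nM. It differs from compound 2 elsewhere too, so this is a weak hint. A moderate rise in the number is expected, a little beyond the scatter, although a step within the scatter remains possible. The expected step is a 2.4-fold higher number from compound 2 to compound 3 (0.37 log units; beyond the scatter). For compound 3 the estimated value is 120 nM, with an expected range of 30 nM to 500 nM.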

Compound 3, half-maximal effective concentration: 2470 nM
Beside the measured number, compound 3's estimate is 21-fold (1.31 log units) below it; the measured number lies above the stated range.
By their numbers in this assay, from the lowest: compound 2; then compound 1; then compound 3.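

On the carbonyl carbon whose other neighbour is the aromatic nitrogen, the choice of group has a strong influence in this assay: the exchange of benzoyl for tert-butoxycarbonyl gives a 48-fold higher number from compound 2 to compound 3 (1.69 log units; beyond the scatter) and so marks this position as highly sensitive to this change. The change removes the six-membered aromatic ring of carbon only and brings in one hydrogen-bond acceptor, with almost the same number of heavy atoms on either side, so the size of the group alone, as counted here, does not track the step. Which of these differences carries the step cannot be told from this one pair, and no measurement on hand accounts for it.

Open, as far as these compounds go, is how other groups on this carbonyl carbon would read: acetyl or cyclohexanecarbonyl would test the loss of the aromatic ring without the added oxygen, while a pyridinecarbonyl group would test a changed aromatic ring. Also open, from the compounds shown here alone, is whether benzoyl in place of tert-butoxycarbonyl on the core of compound 1 would give a step of similar size, or whether this one holds only with the nitrile side chain of compound 2 and compound 3.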